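A few compounds are considered here, and "the series" means these few. Any claim that something is new, unique, unknown or untested is made for them only; others in the source may bear on it.

In a physicochemical assay for solubility (a lower number here means a less soluble compound, a higher number a more soluble compound), three compounds have been measured so far. Compound 1 (`O=S(=O)(Nc1ncccn1)c1ccc2c(c1)OCC[C@@H]2c1ccc(C(F)(F)F)cc1-c1ccc(F)nc1`) gives 408000 nM, compound 2 (`O=S(=O)(Nc1nccs1)c1ccc2c(c1)OCC[C@H]2c1ccc(C(F)(F)F)cc1-n1ccnn1`) gives 154000 nM and compound 3 (`O=C1OCCN1c1cc(C(F)(F)F)ccc1[C@H]1CCOc2cc(S(=O)(=O)Nc3nccs3)ccc21`) gives 295000 nM. Compound 3 is the middle number of the three and lies within the scatter of both other compounds.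

Compound 4 (`O=S(=O)(Nc1nccs1)c1ccc2c(c1)OCC[C@@H]2c1ccc(C(F)(F)F)cc1-c1ccc(F)cn1`) has 5-fluoropyridin-2-yl in place of 2-oxo-1,3-oxazolidin-3-yl on an aromatic carbon, ortho to a large group and meta to a trifluoromethyl group: 5-fluoropyridin-2-yl in place of 2-oxo-1,3-oxazolidin-3-yl on an aromatic carbon.

Among the compounds with values here, no measured pair isolates a single change, so the size of this step cannot be read directly. The expectation rests on compound 2 at 154000 nM and compound 1 at 408000 nM, which carry other groups at this place and remain within the scatter of compound 3. In this assay, the expected 1.3-fold lower number from compound 3 to compound 4 (0.11 log units; within the scatter) is a small one, with no shift beyond the scatter in either direction. Compound 4 is estimated at 230000 nM, with an expected range of 100000 nM to 480000 nM.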

Compound 4, solubility: 7000 nM
Estimate against measurement, compound 4: 33-fold (1.52 log units) above; the whole stated range lies above it.
By their numbers in this assay, from the lowest: compound 4; then compounds 2, 3 and 1 (each within the scatter of the next, the first and the last beyond it).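

In this assay, 5-fluoropyridin-2-yl in place of 2-oxo-1,3-oxazolidin-3-yl, on the aromatic carbon ortho to a large group and meta to a trifluoromethyl group, gives a 42-fold lower number from compound 3 to compound 4 (1.62 log units; beyond the scatter) as the first step read at this position. Within the data shown here, the read-out at this place therefore depends strongly on the group it carries, a point that the earlier compounds, with no single-change pair among them, could not show. No measurement shown bears on the reason for this step.

A single step cannot separate the contribution of the fluorine from that of the aromatic ring as a whole. From the compounds shown here alone, how a simple pyridin-2-yl without fluorine, a dimethylamino group or a carboxylic acid would read at this place in this assay remains open.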